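The source may hold more compounds than are shown below. What is called first, only, known or untested is meant among the compounds shown, and "the series" means these compounds.

Measured compounds:
compound 1 `CCCCCCCC/C=C\CCCCCCCC(=O)Nc1nnc(S[C@@H]2O[C@H](COC(C)=O)[C@H](OC(C)=O)[C@H](OC(C)=O)[C@H]2OC(C)=O)s1` gives "not active" (no number reported) in a functional assay on SK-OV-3 cells (Homo sapiens) for cytotoxicity, read by MTT assay, with a stated time of 24 h; on this read-out higher numbers stand for weaker inhibition and lower numbers for stronger inhibition
compound 2 `CCCCCCCC(=O)Nc1nnc(S[C@@H]2O[C@H](CO)[C@H](O)[C@H](O)[C@H]2O)s1` gives 56000 nM in this assay
compound 3 `CCCCCCCCCCCCCCCCCC(=O)Nc1nnc(S[C@@H]2O[C@H](CO)[C@H](O)[C@H](O)[C@H]2O)s1` gives "not active" (no number reported) in this assay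

Only compound 2 carries a number in this assay; compound 3 and compound 1 are both recorded without one. Compound 3 therefore stands among the entries that gave no measurable inhibition, and the step from compound 2 to compound 3 cannot be sized. Compound 4 `CCCCCCCC/C=C\CCCCCCCCCCCC(=O)Nc1nnc(S[C@@H]2O[C@H](CO)[C@H](O)[C@H](O)[C@H]2O)s1` is not yet measured. It differs from compound 3 by dec-1-en-1-yl in place of hexyl on a saturated chain carbon, ten or more bonds along the chain from a carbonyl carbon. This is a lengthening of the chain with a double bond; compound 1, which likewise carries a double bond in its chain, also gave no number. With two of three neighbours without a number, no step size can be given in this assay; the expectation is that compound 4 stays at the weak end, and most probably returns no number either. Should a number be reported, compound 4 is estimated at 120000 nM, with a range from 30000 nM to 400000 nM.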

Compound 4, half-maximal inhibitory concentration: "not active" (no number reported)
For compound 4 the study gives words and no number, and the estimate cannot be compared.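

For the compounds shown here, compound 4, like compound 3, is recorded with words and no number, so no step between them can be read. The compounds shown leave open whether any chain other than that of compound 2 gives a measurable value. No supporting evidence bears on this result.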